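Compound 2 Gains a Nitro Group

The compounds below may be only part of what the source reports. "The series", "measured", "known", "first", "only" and "open" are said of these compounds alone.

All four compounds share one core. Compound 1 `COc1c(N2CCN(C(c3ccccc3)c3ccc(Cl)cc3)CC2)c(F)cc2c(=O)c(C(=O)O)cn(C3CC3)c12` was examined in an ADME assay on Vero cells (Chlorocebus sabaeus) for cytotoxicity, read by MTT assay, with a stated time of 72 h (a higher number here means a weaker inhibitor, a lower number a stronger inhibitor), and gives "not determined" (no result reported). Compound 2 `COc1c(N2CCc3ccccc3C2C(=O)NC(C)(C)C)c(F)cc2c(=O)c(C(=O)O)cn(C3CC3)c12` was examined in this assay and gives "not determined" (no result reported), so compound 2 stands without a value in this assay. Compound 3 `COc1c(N2CCN(C)C(c3ccccc3)C2)c(F)c([N+](=O)[O-])c2c(=O)c(C(=O)O)cn(C3CC3)c12`, which already carries a nitro group, gives 126000 nM in this assay. Compound 4 `COc1c(N2CCc3ccccc3C2C(=O)NC(C)(C)C)c(F)c([N+](=O)[O-])c2c(=O)c(C(=O)O)cn(C3CC3)c12` has not yet been measured; it differs from compound 2 by nitro in place of hydrogen on an aromatic carbon. Going by the values given here, no step between two measured compounds shows this change, so the size and direction of the step in this assay from compound 2 to compound 4 cannot be read from the data, and with compound 2 itself without a number no gap beyond the usual scatter can be assigned. The one point of reference is compound 3 with its value of 126000 nM. Compound 4 is therefore expected to give 110000 nM in this assay, with a range from 40000 nM to 300000 nM.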

Compound 4, half-maximal inhibitory concentration: 113000 nM
The estimate for compound 4 lay 1.0-fold (0.01 log units) below the measured number; the measured number falls inside the stated range.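

Going by these compounds alone, no step from compound 2 to compound 4 can be read in this assay, with compound 2 carrying no single number there. The compounds shown leave open what nitro in place of hydrogen does to this read-out. No outside data explain the value of compound 4.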